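The source may report more compounds than this note shows. Statements on the series, on what has been measured and on what is new or still open speak of the compounds shown alone.

In a functional assay on K562 cells (Homo sapiens) for antiproliferative activity, read by MTT assay, with a stated time of 5 days (on this read-out lower numbers stand for stronger inhibition and higher numbers for weaker inhibition), compound 1 `COc1ccc(/C=C(/C(=O)c2cc(OC)c(OC)c(OC)c2)c2ccc(N(C)C)cc2)cc1` gives 150000 nM and compound 2 `COc1ccc(/C=C(/C(=O)c2cc(OC)c(OC)c(OC)c2)c2ccccc2O)cc1` gives 370000 nM. Compound 2 therefore holds the higher of the two numbers, and so shows the weaker inhibition. Compound 3 `COc1ccc(/C=C(/C(=O)c2cc(OC)c(OC)c(OC)c2)c2ccccc2)cc1` differs from compound 2 at one place, with hydrogen in place of hydroxy on an aromatic carbon, turning 2-hydroxyphenyl into phenyl (hydrogen in place of hydroxy on an aromatic carbon). For the measured compounds named here, only one measured step bears on this change, since it alters the same group: a 2.5-fold higher number from compound 1 to compound 2 (0.39 log units; beyond the scatter). That step is modest, though beyond the scatter, and it offers no measured comparison for removing the hydroxy alone. No step beyond the scatter is therefore expected in this assay, with at most a slight shift toward lower numbers. The expected change is a 1.4-fold lower number from compound 2 to compound 3 (0.15 log units; within the scatter). Compound 3 is estimated at 260000 nM, with an expected range from 90000 nM to 700000 nM.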

Compound 3, half-maximal inhibitory concentration: 20000 nM
Compound 3: the middle estimate sits 13-fold (1.11 log units) above what was measured, outside the stated range (below it).
By their numbers in this assay, from the lowest: compound 3; then compound 1; then compound 2.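

For the compounds shown here, compounds 1 and 2 compared only two substituted rings, whereas compound 3 supplies the unsubstituted phenyl as a reference. In this assay, replacing the hydroxy with hydrogen gives a 19-fold lower number from compound 2 to compound 3 (1.27 log units; beyond the scatter), a large step at this aromatic carbon, and replacing the dimethylamino with hydrogen gives a 7.5-fold lower number from compound 1 to compound 3 (0.88 log units; beyond the scatter), so compound 3 shows the strongest inhibition of the three and neither substituted ring matches the phenyl. No measurement shown here explains why these groups weaken inhibition.

The compounds shown leave open whether any replacement of hydrogen on this ring raises the number or only hydroxy and dimethylamino do. A fluorine atom or a primary amine on the same ring would help to separate these two possibilities.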